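The source may report more compounds than this note shows. Statements on the series, on what has been measured and on what is new or still open speak of the compounds shown alone.

Compound 1 `COc1ccc2nc(N(Cc3cc(-c4ccc(SC(F)(F)F)cc4)no3)c3nc4ccc(F)cc4s3)sc2c1` and compound 2 `COc1ccc2nc(N(Cc3cc(-c4ccc(OC(F)(F)F)cc4)no3)c3nc4ccc(F)cc4s3)sc2c1` share one core and differ at a single point, (trifluoromethoxy in place of (trifluoromethyl)sulfanyl on an aromatic carbon). In a functional assay on U-937 cells (Homo sapiens) for antiproliferative activity, read by MTT assay (a higher number here means a weaker inhibitor, a lower number a stronger inhibitor), compound 1 gives 42900 nM, and compound 2 gives 23100 nM; the step between them, a 1.9-fold lower number from compound 1 to compound 2 (0.27 log units; within the scatter), is small enough that the two numbers cannot be told apart. Compound 3 `FC(F)(F)Sc1ccc(-c2cc(CN(c3ncccn3)c3nc4ccccc4s3)on2)cc1` is built on a different core; how that core differs from the core of compound 1 is not broken down here. In this assay compound 3 gives 19400 nM, a number close to that of compound 2 and somewhat lower than that of compound 1. For the measured compounds named here, compound 4 `FC(F)(F)Oc1ccc(-c2cc(CN(c3ncccn3)c3nc4ccccc4s3)on2)cc1` has not yet been measured; it carries the same change as the one from compound 1 to compound 2, made on the core of compound 3, (trifluoromethoxy in place of (trifluoromethyl)sulfanyl on an aromatic carbon). Since the earlier instance of this change moved the number by no more than the scatter of the method, the step from compound 3 to compound 4 is expected to be similarly modest, a 1.4-fold lower number from compound 3 to compound 4 (0.14 log units; within the scatter), an expectation that rests on a 1.9-fold lower number from compound 1 to compound 2 (0.27 log units; within the scatter). Compound 4 is therefore estimated at 14000 nM, most likely between 6000 nM and 35000 nM.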

Compound 4, half-maximal inhibitory concentration: 13500 nM
Beside the measured number, compound 4's estimate is 1.0-fold (0.02 log units) above it; measured number inside the range.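

In this assay, putting trifluoromethoxy in place of (trifluoromethyl)sulfanyl on the core of compound 3 gives a 1.4-fold lower number from compound 3 to compound 4 (0.16 log units; within the scatter), so here too the two numbers cannot be told apart. The change behaves alike on the two cores as far as this method can tell: the same change on two cores in this assay, a 1.9-fold lower number (0.27 log units; within the scatter) from compound 1 to compound 2 and a 1.4-fold lower number (0.16 log units; within the scatter) from compound 3 to compound 4, 1.3-fold (0.11 log units) apart, within the scatter of two such steps. This shows that, on these two cores, the change carries over without a step beyond the scatter; it does not show that the two groups are interchangeable throughout the series, as only two cores are shown and steps this small could hide a modest dependence on the core.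

The compounds shown leave open whether a different group on that aromatic carbon, such as a nitrile, an amine or a carboxylic acid, would move the number beyond the scatter on either core. They also leave open whether the two groups would remain indistinguishable on a third core.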